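Acetyl on the ring amine nitrogen: next step

The compounds below may be only part of what the source reports. "The series", "measured", "known", "first", "only" and "open" are said of these compounds alone.

Compound 1 `Nc1ccccc1NC(=O)c1ccc(CNC2=NC(=O)C(c3ccccc3)N2)cc1` gives 8000 nM in an assay for inhibition of histone deacetylase 8 (Homo sapiens), read by fluorescence, with stated times of 15 min and 60 min; a higher number here means a weaker inhibitor, a lower number a stronger inhibitor. Compound 2 `Nc1ccccc1NC(=O)c1ccc(CNC2=NC(=O)C(Cc3ccccc3)N2)cc1` gives 13000 nM in this assay; this is the higher of the two numbers, but with a 1.6-fold higher number from compound 1 to compound 2 (0.21 log units; within the scatter) the two compounds are not separated. Compound 3 `CC(=O)N1C(NCc2ccc(C(=O)Nc3ccccc3N)cc2)=NC(=O)C1Cc1ccccc1` differs from compound 2 by acetyl in place of hydrogen on an amine nitrogen in a ring. For the measured compounds named here, no measured step touches this nitrogen: the only step measured so far concerns benzyl in place of phenyl on a saturated ring carbon and says nothing about what the amine nitrogen in the ring tolerates. The expectation for this assay therefore rests on compound 2 alone, and the step of a 1.2-fold higher number from compound 2 to compound 3 (0.06 log units; within the scatter) is expected to stay within the scatter. No comparable change has been tested, so the bounds are wide. Compound 3 is estimated at 15000 nM, ranging from 5000 nM to 45000 nM.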

Compound 3, half-maximal inhibitory concentration: 22700 nM
Estimate against measurement, compound 3: 1.5-fold (0.18 log units) below; the range from low to high includes it.
By their numbers in this assay, from the lowest: compounds 1, 2 and 3 (each within the scatter of the next, the first and the last beyond it).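

In this assay acetyl on the amine nitrogen in the ring gives a 1.7-fold higher number from compound 2 to compound 3 (0.24 log units; within the scatter) and so does not separate compound 3 from compound 2. For the compounds shown here, this is the first reading at this position: the ring nitrogen, next to the ring atom that bears a benzyl group, carries an acetyl group in place of hydrogen with no step beyond the scatter. No measurement shown here bears on the reason for the size of this step.

As far as these compounds go, whether this tolerance extends to other groups on the same nitrogen stays open, for instance a methyl group, a longer acyl chain such as butanoyl, or an acyl chain ending in a carboxylic acid. From the compounds shown here alone, the acetyl step is also read only with benzyl on the saturated ring carbon, so its size with phenyl there, as in compound 1, remains open.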